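The compounds below may be only part of what the source reports. "The series", "measured", "known", "first", "only" and "open" are said of these compounds alone.

Compound 1 `CCC1=C(O)c2c(oc(-c3ccc(SC)cc3)cc2=O)C(CC)(CC)C1=O`: in a functional assay on KB cells (Homo sapiens) for antiproliferative activity, read by sulforhodamine B assay, with a stated time of 3 days (a higher number here means that more compound is needed for the effect, a lower number that less compound is needed), compound 1 gives > 52.1 uM, which is a limit of the assay rather than a number.
Compound 2 `CCC1=C(O)c2c(oc(-c3ccccc3C)cc2=O)C(CC)(CC)C1=O`: compound 2 gives 40.9 uM.
Compound 3 `CCC1=C(O)c2c(oc(-c3ccc(C)c(F)c3)cc2=O)C(CC)(CC)C1=O`: compound 3 gives 28.1 uM.

Compound 3 holds the lowest of the two numbers; its nearest neighbour is compound 2, and the step is a 1.5-fold lower number from compound 2 to compound 3 (0.16 log units; within the scatter), so no order between these two is claimed. Compound 1 sits at a limit (the limit of > 52.1 uM in this assay, at which 1 of the 3 values shown sits), so an at least 1.2-fold lower number from compound 1 to compound 2 (0.10 log units; that floor lies within the scatter) and an at least 1.8-fold lower number from compound 1 to compound 3 (0.26 log units; that floor lies within the scatter) are floors only.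

Compound 4 `CCC1=C(O)c2c(oc(-c3cc(C)ccc3F)cc2=O)C(CC)(CC)C1=O` differs from compound 3 by 2-fluoro-5-methylphenyl in place of 3-fluoro-4-methylphenyl on an aromatic carbon. For the measured compounds named here, the one measured step between two numeric values that changes the aryl group is a 1.5-fold lower number from compound 2 to compound 3 (0.16 log units; within the scatter), within scatter; the other two steps start from a limit. Nothing measured distinguishes one arrangement of fluorine and methyl on that ring from another. For compound 4 in this assay the expected step is therefore none beyond scatter, a 1.1-fold higher number from compound 3 to compound 4 (0.03 log units; within the scatter). Compound 4 is estimated at 30 uM, in the range 14 uM to 65 uM.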

Compound 4, concentration for half-maximal effect: 47.3 uM
Beside the measured number, compound 4's estimate is 1.6-fold (0.20 log units) below it; low and high end bracket the measured number.
By their numbers in this assay, from the lowest: compounds 3, 2 and 4 (each within the scatter of the next). At a limit, above all of these: compound 1.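

In this assay there is a 1.7-fold higher number from compound 3 to compound 4 (0.23 log units; within the scatter), so this rearrangement of the same atoms on the aryl ring does not separate the two. With a 1.2-fold higher number from compound 2 to compound 4 (0.06 log units; within the scatter), the 2-fluoro-5-methylphenyl group also cannot be told apart from 2-methylphenyl at this position, so no order among compounds 2, 3 and 4 is claimed. Compound 1 stands at a limit rather than a number: the limit of > 52.1 uM in this assay, at which 1 of the 4 values shown sits. Accordingly, an at least 1.1-fold lower number from compound 1 to compound 4 (0.04 log units; that floor lies within the scatter) is a floor only.

From the compounds shown here alone, whether an amine or a carboxylic acid on this aryl ring would move the number beyond the scatter remains open. Also open, going by these compounds, is what a pyridine ring or a longer alkyl chain would do in place of the aryl group.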